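This account rests on a few compounds, and the source may have more. Where it says the series, first, only, none or still open, it means among the compounds named here.

Working notes on the series. In a functional assay on HepG2 cells (Homo sapiens) for antiproliferative activity, read by MTT assay, with a stated time of 72 h (a higher number here means a weaker inhibitor, a lower number a stronger inhibitor), compound 1 `C=C(c1cc(OC)nc(OC)c1)c1ccc(OC)c(O)c1` gives 77 nM, compound 2 `C=C(c1cc(Cl)nc(N(C)C)c1)c1ccc(OC)c(O)c1` gives 27 nM and compound 3 `C=C(c1ccnc(C)c1)c1ccc2[nH]ccc2c1` gives 33 nM. Compound 3 therefore lies within the scatter of compound 2, while compound 1 stands beyond the scatter from it, on the higher side.

The next entry is compound 4 `C=C(c1cc(C)nc(C)c1)c1ccc2[nH]ccc2c1`, which differs from compound 3 in one place: methyl in place of hydrogen on an aromatic carbon. This is a methyl in place of hydrogen on an aromatic carbon, next to the ring nitrogen, on the six-membered aromatic ring with 1 nitrogen that already holds a methyl group.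

Within the data shown here, no measured pair differs in one place only, so the size of this step can only be judged indirectly. Compound 2, at 27 nM, and compound 1, at 77 nM, both carry more than one substituent on their nitrogen-containing ring and still give values in the nanomolar range of compound 3. No change beyond the scatter is therefore expected in this assay, with a slight drift towards a higher number at most.

The estimated step is a 1.2-fold higher number from compound 3 to compound 4 (0.08 log units; within the scatter). For compound 4 the expected value is 40 nM, with an estimated range of 15 nM to 110 nM.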

Compound 4, half-maximal inhibitory concentration: 30 nM
Compound 4: the middle estimate sits 1.3-fold (0.12 log units) above what was measured; measured number inside the range.
By their numbers in this assay, from the lowest: compounds 2, 4 and 3 (each within the scatter of the next); then compound 1.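

Methyl in place of hydrogen on an aromatic carbon, next to the ring nitrogen, gives the first change in the series that can be read at a single place: in this assay it amounts to a 1.1-fold lower number from compound 3 to compound 4 (0.04 log units; within the scatter) and stays within the scatter. On the core of compound 3, this position therefore carries a methyl group with no readable change in antiproliferative activity, and the ring then holds two methyl groups rather than one. No supporting data bear on why the number holds steady at this position.

The compounds shown leave open how far this tolerance extends: on this core, the position is seen only with hydrogen and methyl, so a longer chain such as propyl, a primary amine or a carboxylic acid could behave quite differently. On these data alone, it also remains open whether the same methyl change would give a similarly small step on the core of compound 1 or compound 2, or in a cell line other than the one used here.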